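This account rests on a few compounds, and the source may have more. Where it says the series, first, only, none or still open, it means among the compounds named here.

Measured so far in a functional assay on CHO cells for antagonist activity at adenosine receptor A2b (Homo sapiens), read by 33P incorporation, with a stated time of 20 min; a lower number here means a stronger inhibitor, a higher number a weaker inhibitor:
compound 1 `CCn1c(-c2ccccc2)nc2c(NC3CCC3)ncnc21`: 1440 nM
compound 2 `Cn1c(-c2cccc(Cl)c2)nc2c(NC3CCCC3)ncnc21`: 2530 nM
compound 3 `CCn1c(-c2ccccc2)nc2c(NC3CCCC3)ncnc21`: 5790 nM

Compound 2 sits second highest of the three numbers; compound 2 gives 2530 nM and compound 1 gives 1440 nM, a gap within the scatter, while compound 3 gives 5790 nM, a gap beyond it. Going by the values given here, the one single-point step measured, a 4.0-fold higher number from compound 1 to compound 3 (0.60 log units; beyond the scatter), concerns the ring on the nitrogen and not the aryl group.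

Compound 4 `COc1ccc(-c2nc3c(NC4CCCC4)ncnc3n2C)cc1` differs from compound 2 in the aryl group only: 4-methoxyphenyl in place of 3-chlorophenyl on an aromatic carbon. Among the compounds with values here, no measured step touches this position, so nothing points either way, and the expectation is no change beyond the scatter, with a wide range. Estimated step: a 1.0-fold lower number from compound 2 to compound 4 (0.01 log units; within the scatter). Compound 4 is therefore expected near 2500 nM, between 700 nM and 9000 nM in this assay.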

Compound 4, inhibition constant: > 30000 nM
Compound 4 gave a limit, no number; the forecaster's own chance of this, stated with the estimate: 5%; at least 12-fold (1.07 log units) between middle value and limit.
By their numbers in this assay, from the lowest: compounds 1 and 2 (each within the scatter of the next); then compound 3. At a limit, above all of these: compound 4.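

Compound 4 gives only a limit, not a number, in this assay: the limit of > 30000 nM in this assay, at which 1 of the 4 values shown sits.

The aryl group on this aromatic carbon, between two ring nitrogen atoms, is therefore not a tolerant position: 4-methoxyphenyl in place of 3-chlorophenyl gives an at least 11-fold higher number from compound 2 to compound 4 (1.07 log units; beyond the scatter). Going by these compounds alone, the earlier step concerned only the ring on the nitrogen, so this is the first sign that the series responds to a change here.

Open, from the compounds shown here alone, is whether the methoxy group itself or its place on the phenyl ring drives the step. 3-Methoxyphenyl or 4-chlorophenyl on the same carbon would separate the two.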